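Methyl branching and potency in a thienylmethyl amide series

The source may report more compounds than this note shows. Statements on the series, on what has been measured and on what is new or still open speak of the compounds shown alone.

Working notes. Compound 1 `CCc1ccc(OCC(=O)N(CC)Cc2cccs2)cc1` is the reference; in an assay on HEK293 cells for agonist activity at transient receptor potential cation channel subfamily M member 8 (Homo sapiens), read by fluorescence and calcium flux, with a stated time of 15 min (a lower number here means that less compound is needed, a higher number that more compound is needed for the effect), compound 1 gives 67 nM. Compound 3 `CCN(Cc1cccs1)C(=O)COc1ccc(C(C)C)cc1` gives 397 nM in this assay, and the step of a 5.9-fold higher number from compound 1 to compound 3 (0.77 log units; beyond the scatter) corresponds to methyl in place of hydrogen on a saturated chain carbon bound to an aromatic carbon and a saturated chain carbon. Compound 2 `CCN(Cc1cccs1)C(=O)C(C)Oc1ccc(C)cc1` gives 889 nM; the difference between the core of compound 2 and that of compound 1 is not broken down here. Compound 4 `CCN(Cc1cccs1)C(=O)C(C)(C)Oc1ccc(C)cc1` has not been measured. It differs from compound 2 by methyl in place of hydrogen on a saturated chain carbon bound to a carbonyl carbon, an oxygen on an aromatic ring and a saturated chain carbon. This is the same kind of change as from compound 1 to compound 3, but the place is not the same: there the chain carbon is bound to an aromatic carbon and a saturated chain carbon, here to a carbonyl carbon, an oxygen on an aromatic ring and a saturated chain carbon. Among the measured compounds shown here, only one measured example of the change exists, so the expectation is uncertain. Given that compound 2 already gives 889 nM, the expected step is a 3.0-fold higher number from compound 2 to compound 4 (0.48 log units; beyond the scatter). Compound 4 is estimated at 2700 nM, between 800 nM and 9000 nM.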

Compound 4, half-maximal effective concentration: 11000 nM
For compound 4 the middle estimate is 4.1-fold (0.61 log units) below the measured one, and the stated range ends below it.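

In this assay, methyl in place of hydrogen on the chain carbon gives a 12-fold higher number from compound 2 to compound 4 (1.09 log units; beyond the scatter). Set beside the earlier step, the change goes the same way on both cores and the two sizes cannot be told apart: the same change on two cores in this assay, a 5.9-fold higher number (0.77 log units; beyond the scatter) from compound 1 to compound 3 and a 12-fold higher number (1.09 log units; beyond the scatter) from compound 2 to compound 4, 2.1-fold (0.32 log units) apart, within the scatter of two such steps This rests on two pairs only, with the methyl at a different place in each, and it does not show that the step would hold on any other core or at any other place.

Open, on these data alone, is what a longer chain or an amine would do in place of methyl on the saturated chain carbon bound to a carbonyl carbon, an oxygen on an aromatic ring and a saturated chain carbon.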